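Nitro for chloro on the sulfonamide aryl of compound 1

The source may report more compounds than this note shows. Statements on the series, on what has been measured and on what is new or still open speak of the compounds shown alone.

Three sulfonamides sharing one core have been run through a functional assay on MDA-MB-231 cells (Homo sapiens) for antiproliferative activity, read by MTT assay, with a stated time of 72 h; on this read-out lower numbers stand for stronger inhibition and higher numbers for weaker inhibition. Compound 1 `CCOC(=O)c1oc2ccc(NS(=O)(=O)c3ccc(Cl)cc3)cc2c1C` gives 53900 nM and stands second highest of the three numbers. Among the measured compounds shown here, compound 2 `CCOC(=O)c1oc2ccc(NS(=O)(=O)c3ccc(C(F)(F)F)cc3)cc2c1C` gives 24300 nM, and the step of a 2.2-fold lower number from compound 1 to compound 2 (0.35 log units; beyond the scatter) is the only one-place change measured here. Compound 3 `CCOC(=O)c1oc2ccc(NS(=O)(=O)c3ccccc3C(F)(F)F)cc2c1C` gives 82400 nM, which lies within the scatter of compound 1, so no order between them is claimed; compound 3 and compound 2 differ only in where the trifluoromethyl sits, and their two values show a gap that this account does not read further.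

Compound 4 `CCOC(=O)c1oc2ccc(NS(=O)(=O)c3cccc([N+](=O)[O-])c3)cc2c1C` has not been measured. The change from compound 1 is 3-nitrophenyl in place of 4-chlorophenyl on a sulfonyl sulfur. For the measured compounds named here, the only step that bears on it, from compound 1 to compound 2, was modest, and it swapped one group for another at the same place; the present change also moves the group, which no measured pair covers. The writer therefore expects at most a modest step in this assay, with no direction firmly indicated, so for compound 4 the estimated value is 45000 nM (range 15000 nM to 135000 nM), meaning an expected step of a 1.2-fold lower number from compound 1 to compound 4 (0.08 log units; within the scatter).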

Compound 4, half-maximal inhibitory concentration: 59900 nM
The estimate for compound 4 lay 1.3-fold (0.12 log units) below the measured number, within the range that was stated.
By their numbers in this assay, from the lowest: compound 2; then compounds 1, 4 and 3 (each within the scatter of the next).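

Placing 3-nitrophenyl in place of 4-chlorophenyl on a sulfonyl sulfur in this assay gives a 1.1-fold higher number from compound 1 to compound 4 (0.05 log units; within the scatter), so the two compounds cannot be put in order. Among the compounds shown here, this is the first measured change at this place that alters both the group and where it sits on the aryl ring, and it brings in hydrogen-bond acceptors that the 4-chlorophenyl lacks, yet it produces no step beyond the scatter, unlike a 2.2-fold lower number from compound 1 to compound 2 (0.35 log units; beyond the scatter) on the same aryl ring. No supporting data are available to explain this result.

The compounds shown leave open whether the identity of the group or its place on the aryl ring matters more, as the nitro change combines the two. They also leave open how an amine or a carboxylic acid on that ring would read in this assay and whether either would separate from compound 1.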